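Swapping the Amine Substituent: From Compound 2 to Compound 3

This account rests on a few compounds, and the source may have more. Where it says the series, first, only, none or still open, it means among the compounds named here.

Compound 1, `COc1cc2c(cc1OCC(O)CN1CCN(C(=O)C3CCCO3)CC1)C(=O)C(C)OC2`: 195 nM
Compound 2, `COc1ccc2c(c1OCC(O)CN1CCN(c3ccccc3)CC1)COC(C)C2=O`: 296 nM

Of the compounds shown here, two have been measured in an assay on isolated protein (strain SPF) for antagonist activity at Alpha-1D adrenergic receptor (Rattus norvegicus); on this read-out lower numbers stand for tighter binding and higher numbers for weaker binding. Compound 1 `COc1cc2c(cc1OCC(O)CN1CCN(C(=O)C3CCCO3)CC1)C(=O)C(C)OC2` gives 195 nM, and compound 2 `COc1ccc2c(c1OCC(O)CN1CCN(c3ccccc3)CC1)COC(C)C2=O` gives 296 nM. Compound 2 holds the higher of the two numbers, yet its gap to compound 1 lies within the scatter, so the two cannot be ordered. Compound 3 `COc1ccc2c(c1OCC(O)CN1CCN(C(=O)C3CCCO3)CC1)COC(C)C2=O` differs from compound 2 by (oxolan-2-yl)carbonyl in place of phenyl on an amine nitrogen in a ring. Since compound 1 already carries the entering group and in this assay compound 1 gives 195 nM, no step beyond the scatter is expected; the expected step is a 1.3-fold lower number from compound 2 to compound 3 (0.13 log units; within the scatter). Compound 3 is estimated at 220 nM, within a range from 90 nM to 550 nM.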

Compound 3, dissociation constant: 340 nM
Compound 3: the middle estimate sits 1.5-fold (0.19 log units) below what was measured; the range from low to high includes it.
By their numbers in this assay, from the lowest: compounds 1, 2 and 3 (each within the scatter of the next).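

In this assay, for the compounds shown here, placing (oxolan-2-yl)carbonyl instead of phenyl on the amine nitrogen in a ring gives a 1.1-fold higher number from compound 2 to compound 3 (0.06 log units; within the scatter), the first direct reading at this position. On this core, the read-out does not separate an aromatic carbon ring with no hydrogen-bond acceptors from a five-membered non-aromatic ring group with two. No measurement at hand explains this result. On these data alone, it remains open whether a benzyl group, a simple methyl or a longer alkyl chain on this nitrogen would also stay within the scatter, or whether a free amine hydrogen there would shift the number.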